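Swapping the hydroxamic acid arm for a phenyltriazole

This account rests on a few compounds, and the source may have more. Where it says the series, first, only, none or still open, it means among the compounds named here.

The series shares one core, seen in compound 1 `COC(=O)c1ccc(COc2ccc(CNC(=O)[C@@H]3CCC(=O)N3Cc3ccccc3)cc2)cc1`, and varies only the group at the far end of the benzyloxy arm. In an assay on HEK293 cells for inhibition of Ataxin-2 (Mus musculus), read by fluorescence and Amplex Red (on this read-out higher numbers stand for weaker inhibition and lower numbers for stronger inhibition), compound 1 gives only the assay limit of > 5000 nM. Compound 2 `O=C(O)c1ccc(COc2ccc(CNC(=O)[C@@H]3CCC(=O)N3Cc3ccccc3)cc2)cc1`, the free acid, gives 4500 nM in this assay, a shift of an at least 1.1-fold lower number from compound 1 to compound 2 (0.04 log units; that floor lies within the scatter). Compound 3 `O=C(NO)c1ccc(COc2ccc(CNC(=O)[C@@H]3CCC(=O)N3Cc3ccccc3)cc2)cc1`, bearing the hydroxamic acid, gives 700 nM, the lowest number among the measured compounds; the change amounts to an at least 7.1-fold lower number from compound 1 to compound 3 (0.85 log units; beyond the scatter) and to a 6.4-fold lower number from compound 2 to compound 3 (0.81 log units; beyond the scatter). Compound 3 is thus separated from compound 2 by a gap beyond the scatter, while compound 1 is known only as a limit (the limit of > 5000 nM in this assay, at which 1 of the 3 values shown sits).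

Compound 4 `O=C(NCc1ccc(OCc2cn(-c3ccccc3)nn2)cc1)[C@@H]1CCC(=O)N1Cc1ccccc1` differs from compound 3 in one place: 1-phenyl-1H-1,2,3-triazol-4-yl in place of 4-(hydroxycarbamoyl)phenyl on a saturated chain carbon bound to an oxygen on an aromatic ring. The two measured steps that bear on this are those that installed the hydroxamic acid, and both were modest and beyond the scatter. Removing that group entirely is therefore expected to reverse them, giving a higher number, estimated as a 5.7-fold higher number from compound 3 to compound 4 (0.76 log units; beyond the scatter). For compound 4 the estimate in this assay is 4000 nM, with a range from 1500 nM to 12000 nM, and a real chance that only the limit is reported.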

Compound 4, half-maximal inhibitory concentration: > 5000 nM
Compound 4 was reported as a limit; the forecaster's own chance of this, stated with the estimate: 40%; at least 1.2-fold (0.09 log units) between middle value and limit.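

In this assay, the 1-phenyl-1H-1,2,3-triazol-4-yl group does not hold the level reached with the 4-(hydroxycarbamoyl)phenyl group, with an at least 7.1-fold higher number from compound 3 to compound 4 (0.85 log units; beyond the scatter), so the arm of compound 3 cannot be exchanged for this triazole without a loss beyond the scatter. Set against the 4-carboxyphenyl group, the same replacement gives an at least 1.1-fold higher number from compound 2 to compound 4 (0.04 log units; that floor lies within the scatter), a floor that does not separate the triazole from the free acid, so compound 3 remains the only one of the four that stands clearly apart. Compound 4 joins compound 1 at the limit of the assay, and the step between these two cannot be read: the limit of > 5000 nM in this assay, at which 2 of the 4 values shown sit.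

The change swaps the ring and removes the hydroxycarbamoyl group at once, so the compounds shown cannot say which of the two accounts for the higher number. A hydroxamic acid carried on the phenyl ring of the triazole arm would separate the two, and a carboxylic acid or methyl ester on that ring would show whether the triazole arm follows the order seen among compound 1, compound 2 and compound 3.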